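A few compounds are considered here, and "the series" means these few. Any claim that something is new, unique, unknown or untested is made for them only; others in the source may bear on it.

Compound 1 `CC(=O)O[C@H]1[C@@H](C)/C=C/C(C)(C)[C@H](O)C[C@@H](O)/C(C)=C/[C@H]2[C@@H](OC(=O)c3ccccc3)[C@@H](C)C[C@@]21O`: > 10000 nM (a limit)
Compound 2 `CC(=O)O[C@@H]1C[C@@H](OC(C)=O)C(C)(C)/C=C/[C@H](C)[C@H](OC(C)=O)[C@@]2(O)C[C@H](C)[C@H](OC(=O)c3ccccc3)[C@@H]2/C=C/1C`: 13400 nM
Compound 3 `CC(=O)O[C@@H]1[C@H](C)/C=C/C(C)(C)C(=O)C[C@@H](OC(=O)c2ccccc2)/C(CO)=C/[C@H]2[C@@H](OC(=O)c3ccccc3)[C@H](C)C[C@]12OC(C)=O`: > 10000 nM (a limit)

These three were tested in a functional assay on MDA-MB-231 cells (Homo sapiens) for cytotoxicity, read by MTT assay; a higher number here means a weaker inhibitor, a lower number a stronger inhibitor. Compound 1 reaches only a limit of the assay, > 10000 nM. Compound 2 gives a number, 13400 nM. Compound 3 again shows only a limit, > 10000 nM, so it sits at the limit of > 10000 nM in this assay, at which 2 of the 3 values shown sit, rather than at a measured value. No pair of these compounds differs in a single place, so no measured step is available. Compound 4 `CC(=O)O[C@@H]1[C@H](C)/C=C/C(C)(C)C(=O)C[C@@H](OC(=O)c2ccccc2)/C(C)=C/[C@H]2[C@@H](OC(=O)c3ccccc3)[C@H](C)C[C@]12OC(C)=O` differs from compound 3 by hydrogen in place of hydroxy on a saturated chain carbon bound to a double-bonded ring carbon. In this assay the step that the limit leaves unreadable from compound 3 to compound 4 is expected to stay within the scatter, in no clear direction. Compound 4 is therefore estimated at 15000 nM, in a range from 7000 nM to 40000 nM, most likely again as a limit.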

Compound 4, half-maximal inhibitory concentration: > 10000 nM
Compound 4 was reported as a limit; the forecaster's own chance of this, stated with the estimate: 60%; the middle value lies beyond the limit too.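

Compound 3 and compound 4 both stop at an assay limit, so the step from hydroxymethyl to methyl between them cannot be read: the limit of > 10000 nM in this assay, at which 3 of the 4 values shown sit.

The compounds shown leave open whether this change affects potency at all in this assay.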